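The source may report more compounds than this note shows. Statements on the series, on what has been measured and on what is new or still open speak of the compounds shown alone.

Measured so far:
- compound 1 `Cc1ccc(/C=C/c2ccc(F)c(F)c2)cc1`: 2600 nM
- compound 2 `COc1ccc(/C=C/c2ccc(F)c(F)c2)cc1`: a limit, > 15000 nM
- compound 3 `Fc1ccc(/C=C/c2cccc(F)c2)cc1`: 650 nM

All three were tested in an assay on HepG2 cells for activation of nuclear factor erythroid 2-related factor 2 (Homo sapiens), read by a luciferase reporter, with a stated time of 5 h; on this read-out higher numbers stand for an effect only at larger amounts of compound and lower numbers for an effect already at smaller amounts. Compound 3 gives the lowest of the two numbers; compound 1 gives a higher number. For compound 2 this assay reports only a limit of > 15000 nM in this assay, at which 1 of the 3 values shown sits, and no number.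

Compound 4 `Fc1ccc(/C=C/c2ccc(F)c(F)c2)cc1` differs from compound 3 by a single change: fluoro in place of hydrogen on an aromatic carbon. For the measured compounds named here, the only step between measured compounds that differ in one place is an at least 5.7-fold higher number from compound 1 to compound 2 (0.76 log units; beyond the scatter), and it concerns an exchange of methyl for methoxy, not the addition of a fluorine, so it does not bear directly on the change from compound 3 to compound 4. Going by the values given here, compound 1 and compound 3 differ in two places, so their values show only that compound 3 sits lower.

Among the compounds with values here, with no measured step that speaks to adding a fluoro group, the step of no change at the digits printed from compound 3 to compound 4 (within the scatter) is expected to stay within the scatter. Compound 4 is therefore estimated at 650 nM, between 250 nM and 1700 nM.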

Compound 4, half-maximal effective concentration: > 15000 nM
Compound 4 gave a limit, no number; the forecaster's own chance of this, stated with the estimate: 5%; middle value at least 23-fold (1.36 log units) away from the limit.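

Adding a single fluoro group on an aromatic carbon, ortho to a fluoro group and para to a group of 9 heavy atoms, gives an at least 23-fold higher number from compound 3 to compound 4 (1.36 log units; beyond the scatter), so a change of one heavy atom at this position can matter far more than the scatter. The other readable exchange, fluoro in place of methyl on an aromatic carbon, gives an at least 5.7-fold higher number from compound 1 to compound 4 (0.76 log units; beyond the scatter), which shows that methoxy is not the only replacement for methyl that is linked to a higher number. The value of compound 4 is a limit, shared with compound 2, so the step between these two cannot be read: the limit of > 15000 nM in this assay, at which 2 of the 4 values shown sit.

The compounds shown leave open how a chloro group, an amine or a carboxylic acid would behave at this position. They also leave open whether the added fluoro group would have the same effect on a core carrying other groups.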